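Ethoxy for 4-chlorophenyl on the carbonyl: cytotoxicity notes

The compounds below may be only part of what the source reports. "The series", "measured", "known", "first", "only" and "open" are said of these compounds alone.

- Compound 1 `COc1ccc(C(=O)CSc2nc(O)c(C)c(Cc3cccc4ccccc34)n2)cc1`: > 290000 nM (a limit)
- Compound 2 `Cc1c(O)nc(SCC(=O)c2ccc(Cl)cc2)nc1Cc1cccc2ccccc12`: >= 198000 nM (a limit)

Both entries come from a functional assay on MT4 cells (Homo sapiens) for cytotoxicity; a higher number here means that more compound is tolerated, a lower number that less compound is tolerated. Compound 2 stands only at a limit, >= 198000 nM, and has no numerical value in this assay. Compound 1 likewise gives only a limit, > 290000 nM.

Compound 3 `CCOC(=O)CSc1nc(O)c(C)c(Cc2cccc3ccccc23)n1` carries ethoxy in place of 4-chlorophenyl on a carbonyl carbon.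

Within the data shown here, the only measured step is a step that the two limits leave unreadable from compound 1 to compound 2, with chloro in place of methoxy on an aromatic carbon. It gives no size and concerns a different change, so it offers no firm guide to this one. Neither size nor direction is secure, though a modest fall in tolerated concentration is allowed for, and another limit would not surprise.

The expected step is an at least 1.3-fold lower number from compound 2 to compound 3 (0.12 log units; that floor lies within the scatter). For compound 3 the estimated value is 150000 nM, with an expected range of 50000 nM to 300000 nM.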

Compound 3, half-maximal cytotoxic concentration: >= 287000 nM
Compound 3: no number, only a limit (the forecaster's own chance of this, stated with the estimate: 55%); middle value at least 1.9-fold (0.28 log units) away from the limit.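

In this assay compound 3 gives only a limit, >= 287000 nM. Compound 1 and compound 2 also stand at limits, so the steps from either to compound 3 cannot be read. The compounds shown leave open whether ethoxy in place of 4-chlorophenyl changes the half-maximal cytotoxic concentration at all.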